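The source may report more compounds than this note shows. Statements on the series, on what has been measured and on what is new or still open speak of the compounds shown alone.

Measured compounds:
Compound 1, `Cc1cc(NC(=O)Nc2ccc(F)c(F)c2)c2ccccc2n1`: in an ADME assay on Raji cells (Homo sapiens) for cytotoxicity, with a stated time of 72 h (on this read-out lower numbers stand for an effect already at smaller amounts and higher numbers for an effect only at larger amounts of compound), compound 1 gives > 25000 nM, a limit of the assay.
Compound 2, `Cc1cc(NC(=O)Nc2ccc(F)cc2)c2ccccc2n1`: in this assay compound 2 gives > 25000 nM, again a limit.
Compound 3, `Cc1cc(NC(=O)Nc2ccc(F)cc2F)c2ccccc2n1`: in this assay compound 3 gives > 25000 nM, again a limit.

Compound 2 thus stands at the limit of this assay, and the two further values shown are limits as well, so no order among the three compounds can be read, as the limit of > 25000 nM in this assay, at which 3 of the 3 values shown sit, records. The steps a step that the two limits leave unreadable from compound 1 to compound 2 and a step that the two limits leave unreadable from compound 2 to compound 3 are both unreadable in size for the same reason.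

Compound 4, `Cc1cc(NC(=O)Nc2ccc(Cl)cc2)c2ccccc2n1`, differs from compound 2 by chloro in place of fluoro on an aromatic carbon. Within the data shown here, no measured step gives a readable size for a change on this ring; both measured changes there left the read-out at the limit, as the limit of > 25000 nM in this assay, at which 3 of the 3 values shown sit, shows. The expectation for compound 4 is therefore no step beyond the scatter, with the value most likely at the limit once more. The step from compound 2 expected is a step that the limit leaves unreadable from compound 2 to compound 4. For compound 4 in this assay the estimate is 40000 nM, in the range 15000 nM to 120000 nM.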

Compound 4, half-maximal effective concentration: > 25000 nM
Compound 4: only a limit was reported; the forecaster's own chance of this, stated with the estimate: 85%; the middle value does not contradict the limit.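

No new step can be read: compound 2 and compound 4 both stand at a limit in this assay, so the size of the change between them stays unknown: the limit of > 25000 nM in this assay, at which 4 of the 4 values shown sit.

The compounds shown leave open whether the 4-fluorophenyl to 4-chlorophenyl change, or any other change on this ring, alters the read-out in this assay.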